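Chain extension toward the hydroxypyrrolidine in compound 4

The source may report more compounds than this note shows. Statements on the series, on what has been measured and on what is new or still open speak of the compounds shown alone.

Compound 1 `N#Cc1cccc(-c2ccc(CN(CCN3CCCC3)C(=O)Nc3ccc(F)c(Cl)c3)cc2)c1` in a functional assay for antagonist activity at melanin-concentrating hormone receptor 2 (Homo sapiens) (a higher number here means a weaker inhibitor, a lower number a stronger inhibitor), reaches only a limit, > 3000 nM.
Compound 2 `C[C@H](c1ccc(-c2cccc(C#N)c2)cc1)N(CC(=O)Nc1cc(Cl)cc(Cl)c1)C(=O)CCN1CC[C@H](O)C1` likewise gives only a limit, > 3000 nM.
Compound 3 `C[C@@H](c1ccc(-c2cccc(C#N)c2)cc1)N(CC(=O)Nc1cc(Cl)cc(Cl)c1)C(=O)CCN1CC[C@H](O)C1` also gives only a limit, > 3000 nM.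

Compound 2 thus stands at the assay limit, as do both other measured values. The step that the two limits leave unreadable from compound 2 to compound 3 cannot be read because of the limit of > 3000 nM in this assay, at which 3 of the 3 values shown sit, although (the fact that compounds 2 and 3 differ only in the configuration as drawn). Compound 4 `C[C@H](c1ccc(-c2cccc(C#N)c2)cc1)N(CC(=O)Nc1cc(Cl)cc(Cl)c1)C(=O)CCCN1CC[C@H](O)C1` differs from compound 2 by (3-hydroxypyrrolidin-1-yl)methyl in place of 3-hydroxypyrrolidin-1-yl on a saturated chain carbon, two bonds along the chain from a carbonyl carbon. Within the data shown here, no measured step bears on this kind of change; the single step in hand, from compound 2 to compound 3, is itself unreadable. Among the measured compounds shown here, nothing among the measured values points to a gain, so compound 4 is expected to stay at the limit, the expected step being a step that the limit leaves unreadable from compound 2 to compound 4. The estimate for compound 4 is 6000 nM, with a range of 2000 nM to 30000 nM.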

Compound 4, inhibition constant: > 3000 nM
Compound 4 was reported as a limit (the forecaster's own chance of this, stated with the estimate: 80%); the middle value is on the limit's open side.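

Among these compounds, compound 4 gives > 3000 nM, which is a limit; with compound 2 also at a limit, no step between the two can be read. The compounds shown leave open whether chain length or configuration affects activity, since none gives a value beyond a limit.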